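Thiophen-2-yl in place of pyridin-4-yl: an expectation

The source may hold more compounds than are shown below. What is called first, only, known or untested is meant among the compounds shown, and "the series" means these compounds.

Compound 1 `O=C(CCCCCCC(=O)Nc1nnc(-c2ccncc2)s1)NO` gives 4150 nM in a functional assay on K562 cells (Homo sapiens) for antiproliferative activity, read by MTT assay, with a stated time of 48 h; on this read-out higher numbers stand for weaker inhibition and lower numbers for stronger inhibition.
Compound 2 `O=C(CCCCCC(=O)Nc1nnc(-c2ccncc2)s1)NO` sits at the assay limit, > 60000 nM in this assay.
Compound 3 `O=C(CCCCCC(=O)Nc1nnc(-c2cccnc2)s1)NO` sits at the assay limit, > 60000 nM in this assay.

Among the compounds with values here, compound 1 holds the only number among the three measured compounds; the other two stand at the limit of > 60000 nM in this assay, at which 2 of the 3 values shown sit. Shortening the chain, an at least 14-fold higher number from compound 1 to compound 2 (1.16 log units; beyond the scatter), is the one readable step, and the swap of pyridinyl isomers, a step that the two limits leave unreadable from compound 2 to compound 3, is hidden between two limits.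

Compound 4 `O=C(CCCCCCC(=O)Nc1nnc(-c2cccs2)s1)NO` differs from compound 1 as follows: thiophen-2-yl in place of pyridin-4-yl on an aromatic carbon. No measured step touches this change; the only ring swap shown, between compound 2 and compound 3, left both values at the limit and tells nothing about size or direction. With the seven-carbon chain of compound 1 kept, compound 4 is expected to stay in the same region, a 1.2-fold higher number from compound 1 to compound 4 (0.08 log units; within the scatter), with the estimate for compound 4 in this assay at 5000 nM, between 1500 nM and 20000 nM.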

Compound 4, half-maximal inhibitory concentration: 1560 nM
Compound 4: the middle estimate sits 3.2-fold (0.51 log units) above what was measured; low and high end bracket the measured number.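

Thiophen-2-yl in place of pyridin-4-yl gives a 2.7-fold lower number from compound 1 to compound 4 (0.42 log units; beyond the scatter) in this assay, so this position, on an aromatic carbon next to the ring sulfur of the shared core, responds to a ring swap when the chain of compound 1 is kept. Within the data shown here, the earlier ring swap cannot be read, since compound 2 and compound 3 both stand at a limit, and this is the first size and direction seen for a change here. For this pair, the ring nitrogen of pyridin-4-yl is not required for activity, and a five-membered aromatic ring with sulfur serves better.

On these data alone, it remains open whether phenyl or furan-2-yl at this place would follow thiophen-2-yl, and whether thiophen-2-yl on the shorter chain of compound 2 would bring a readable number. Nothing in the data shown gives a cause for this step.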